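Swapping the benzylic aryl group on a bis(trifluoromethyl)sulfonamide

The compounds below may be only part of what the source reports. "The series", "measured", "known", "first", "only" and "open" are said of these compounds alone.

Compound 1 `O=S(=O)(NCCCNCc1ccccc1Cl)c1cc(C(F)(F)F)cc(C(F)(F)F)c1`: 20000 nM
Compound 2 `O=S(=O)(NCCCNCc1ccc(Cl)c(Cl)c1)c1cc(C(F)(F)F)cc(C(F)(F)F)c1`: 4700 nM
Compound 3 `COc1ccc(CNCCCNS(=O)(=O)c2cc(C(F)(F)F)cc(C(F)(F)F)c2)cc1OC`: 2700 nM

All three share one core and differ only in the aryl ring on the saturated chain carbon bound to an amine nitrogen. In a functional assay on HT-29 cells (Homo sapiens) for inhibition, read by MTT assay, with a stated time of 72 h (on this read-out lower numbers stand for stronger inhibition of growth and higher numbers for weaker inhibition of growth), compound 3 gives the lowest number of the three, though the step of a 1.7-fold lower number from compound 2 to compound 3 (0.24 log units; within the scatter) is within the scatter, while a 7.4-fold lower number from compound 1 to compound 3 (0.87 log units; beyond the scatter) is beyond it. Compound 4 `O=S(=O)(NCCCNCc1ccc(Cl)c(C(F)(F)F)c1)c1cc(C(F)(F)F)cc(C(F)(F)F)c1` carries 4-chloro-3-(trifluoromethyl)phenyl in place of 3,4-dimethoxyphenyl on a saturated chain carbon bound to an amine nitrogen. The nearest comparison is compound 2, whose ring also bears two groups at the 3- and 4-positions, and the step of a 1.7-fold lower number from compound 2 to compound 3 (0.24 log units; within the scatter) was small. Compound 4 is therefore expected to land close to compounds 2 and 3, with an estimated step of a 1.5-fold higher number from compound 3 to compound 4 (0.17 log units; within the scatter) in this assay. The estimate for compound 4 is 4000 nM, ranging from 1500 nM to 11000 nM.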

Compound 4, concentration for 50% growth inhibition: 11000 nM
For compound 4 the middle estimate is 2.8-fold (0.44 log units) below the measured one, within the range that was stated.
By their numbers in this assay, from the lowest: compounds 3 and 2 (each within the scatter of the next); then compounds 4 and 1 (each within the scatter of the next).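

At this position, a single change of trifluoromethyl in place of chloro on an aromatic carbon is enough to register, with a 2.3-fold higher number from compound 2 to compound 4 (0.37 log units; beyond the scatter), and 4-chloro-3-(trifluoromethyl)phenyl in place of 3,4-dimethoxyphenyl gives a 4.1-fold higher number from compound 3 to compound 4 (0.61 log units; beyond the scatter). Against the 2-chlorophenyl ring, a 1.8-fold lower number from compound 1 to compound 4 (0.26 log units; within the scatter) stays within the scatter, so those two cannot be ordered. Nothing available here explains these differences. Still open, from the compounds shown here alone, is how an aryl ring carrying a nitrile or a carboxylic acid would behave in this place. Also open, going by these compounds, is what a longer chain would do to the growth inhibition.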